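Aryl replacement on the shared core: compound 1 to compound 4

A few compounds are considered here, and "the series" means these few. Any claim that something is new, unique, unknown or untested is made for them only; others in the source may bear on it.

Compound 1 `CCC1=C(O)c2c(oc(-c3ccc(SC)cc3)cc2=O)C(CC)(CC)C1=O` carries the 4-(methylsulfanyl)phenyl group on the shared core, and in a functional assay on KBVIN cells (Homo sapiens) for antiproliferative activity, read by sulforhodamine B assay, with a stated time of 3 days (a higher number here means that more compound is needed for the effect, a lower number that less compound is needed), compound 1 gives 1.38 uM. Two other compounds of the series have been measured. Compound 2 `CCC1=C(O)c2c(oc(-c3cccc(C(F)(F)F)c3)cc2=O)C(CC)(CC)C1=O` gives 5.42 uM in this assay, and compound 3 `CCC1=C(O)c2c(oc(-c3ccccc3C(F)(F)F)cc2=O)C(CC)(CC)C1=O` gives 43.1 uM. Compound 1 stands at the lowest number of the three; the gap to compound 2 and the larger gap to compound 3 both lie beyond the usual scatter. For the measured compounds named here, no pair among the measured compounds differs in one place only, so no single-point step can be read from them.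

Compound 4 `CCC1=C(O)c2c(oc(-c3ccc(OC)c(C)c3)cc2=O)C(CC)(CC)C1=O` has not been measured in this assay. Its change from compound 1 is 4-methoxy-3-methylphenyl in place of 4-(methylsulfanyl)phenyl on an aromatic carbon. Both groups are counted with one hydrogen-bond acceptor and no donor, and the ring type is unchanged, so the step is expected to be small. A modest move toward a higher number in this assay is expected, with no change beyond the scatter remaining well possible. The expected step from compound 1 to compound 4 is a 1.8-fold higher number from compound 1 to compound 4 (0.26 log units; within the scatter). Compound 4 is estimated at 2.5 uM in this assay, within a range from 0.8 uM to 8 uM.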

Compound 4, concentration for half-maximal effect: 0.1 uM
For compound 4 the middle estimate is 25-fold (1.40 log units) above the measured one, and the stated range ends above it.
By their numbers in this assay, from the lowest: compound 4; then compound 1; then compound 2; then compound 3.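

In this assay, the aryl group on the shared core proves able to carry the series well past the earlier numbers: 4-methoxy-3-methylphenyl in place of 4-(methylsulfanyl)phenyl gives a 14-fold lower number from compound 1 to compound 4 (1.14 log units; beyond the scatter) and places compound 4 at 0.1 uM as the lowest number of the four. The counts do not separate the two groups, since each has one six-membered aromatic ring of carbon only, no hydrogen-bond donor and one acceptor, yet the step is large, so a match in these counts says little about the outcome at this position. Nothing at hand gives a measured basis for the size of this step.

The step joins two differences, oxygen for sulfur in the 4-substituent and the added 3-methyl, and the compounds shown cannot divide it between them, as neither 4-methoxyphenyl nor 4-(methylsulfanyl)-3-methylphenyl is among them. Also open, going by these compounds, is how the series responds when a dimethylamino group, a carboxylic acid or a longer alkoxy chain such as butoxy stands in place of the methoxy group.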